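The compounds below may be only part of what the source reports. "The series", "measured", "known", "first", "only" and "open" are said of these compounds alone.

Series notes, inhibition of cytochrome P450 11B2.

Compound 1 `Fc1cc2nc(-c3cncnc3C(F)F)n(C3CC3)c2cc1F` and compound 2 `Fc1cc2nc(-c3cncnc3C(F)(F)F)n(C3CC3)c2cc1F` share one core; compound 3 `N#Cc1ccc2nc(-c3cncnc3C(F)F)n(C3CC3)c2c1` and compound 4 `N#Cc1ccc2nc(-c3cncnc3C(F)(F)F)n(C3CC3)c2c1` share another. In an assay on cells for inhibition of cytochrome P450 11B2, mitochondrial (Homo sapiens), read by HPLC, with a stated time of 90 min (a higher number here means a weaker inhibitor, a lower number a stronger inhibitor), compound 1 gives 18 nM and compound 2 gives 25 nM. The structural difference between them is fluoro in place of hydrogen on a saturated chain carbon bound to an aromatic carbon and two fluorine atoms and the measured step is a 1.4-fold higher number from compound 1 to compound 2 (0.14 log units; within the scatter). In this assay compound 3 gives 9 nM; its gap to compound 1 lies within the scatter, its gap to compound 2 beyond it. The difference between the core of compound 3 and the core of compound 1 is not broken down here.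

Compound 4 has no number yet. From compound 3 to compound 4 the change is fluoro in place of hydrogen on a saturated chain carbon bound to an aromatic carbon and two fluorine atoms; the place reads the same as in the pair from compound 1 to compound 2, so this is the same change made a second time, the only two occurrences among the four compounds. For the measured compounds named here, the one measured instance, a 1.4-fold higher number from compound 1 to compound 2 (0.14 log units; within the scatter), sits within the scatter, so the step from compound 3 to compound 4 in this assay is expected to be of similar size, a 1.3-fold higher number from compound 3 to compound 4 (0.12 log units; within the scatter), with nothing in the three measured compounds pointing to a larger shift. Whether the core of compound 3 carries the change in the same way cannot be checked from these data, so the range is kept wide. For compound 4 in this assay the estimate is 12 nM, expected to fall between 6 nM and 25 nM.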

Compound 4, half-maximal inhibitory concentration: 16 nM
Compound 4: the middle estimate sits 1.3-fold (0.12 log units) below what was measured; the range from low to high includes it.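

Difluoromethyl to trifluoromethyl can now be read on two cores in this assay, and the new step is a 1.8-fold higher number from compound 3 to compound 4 (0.25 log units; within the scatter). Set beside the earlier step, the same change shows no difference in size between the two cores that can be separated from the scatter: the same change on two cores in this assay, a 1.4-fold higher number (0.14 log units; within the scatter) from compound 1 to compound 2 and a 1.8-fold higher number (0.25 log units; within the scatter) from compound 3 to compound 4, 1.3-fold (0.11 log units) apart, within the scatter of two such steps. For the compounds shown here, this supports carrying the step from one of these cores to the other as a first estimate, but with only two pairs, each within the scatter, it shows neither a real effect of the change on either core nor that a third core would respond in the same way.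

The compounds shown leave open whether a group other than difluoromethyl or trifluoromethyl at this place, such as a methyl, an amine or a longer chain, would give a step beyond the scatter. They also leave open which part of the difference between the core of compound 1 and the core of compound 3 accounts for the values of those compounds, since the two cores are not linked by a single change.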